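Swapping One Five-Membered Ring for Another

A few compounds are considered here, and "the series" means these few. Any claim that something is new, unique, unknown or untested is made for them only; others in the source may bear on it.

In an ADME assay on BJ cells (Homo sapiens) for cytotoxicity, read by MTT assay, with a stated time of 72 h (on this read-out lower numbers stand for higher toxicity in this test and higher numbers for lower toxicity in this test), three compounds have been measured:
Compound 1, `OC[C@H]1O[C@@H](n2cc(F)c3c(-c4ccco4)ncnc32)[C@H](O)[C@@H]1O`: 310 nM
Compound 2, `OC[C@H]1O[C@@H](n2cc(F)c3c(-c4ccoc4)ncnc32)[C@H](O)[C@@H]1O`: 350 nM
Compound 3, `OC[C@H]1O[C@@H](n2cc(F)c3c(-c4ccsc4)ncnc32)[C@H](O)[C@@H]1O`: 620 nM

Compound 1 gives the lowest of the three numbers, yet neither step away from it reaches beyond the scatter: a 1.1-fold higher number from compound 1 to compound 2 (0.05 log units; within the scatter) and a 2.0-fold higher number from compound 1 to compound 3 (0.30 log units; within the scatter). The remaining pair behaves alike, a 1.8-fold higher number from compound 2 to compound 3 (0.25 log units; within the scatter). Each of these steps exchanges one five-membered aromatic ring on the shared core for another, and none of them moves the cytotoxicity read-out more than repeated measurement would.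

Compound 4, `OC[C@H]1O[C@@H](n2cc(F)c3c(-c4nccs4)ncnc32)[C@H](O)[C@@H]1O`, continues this series with 1,3-thiazol-2-yl in place of furan-2-yl on an aromatic carbon. Going by the values given here, the three measured steps are the only guidance, and all three are exchanges of the same kind that stayed within the scatter. Compound 4 is therefore expected to stay close to compound 1, with a step of a 1.3-fold higher number from compound 1 to compound 4 (0.11 log units; within the scatter) in this assay that should not count as a real change. The estimate for compound 4 in this assay is 400 nM, with a range from 180 nM to 900 nM.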

Compound 4, half-maximal cytotoxic concentration: 630 nM
Compound 4: middle estimate off by 1.6-fold (0.20 log units), on the low side; low and high end bracket the measured number.
By their numbers in this assay, from the lowest: compounds 1, 2, 3 and 4 (each within the scatter of the next, the first and the last beyond it).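

With compound 4, this position gives its first step beyond the scatter in this assay, a modest one: a 2.0-fold higher number from compound 1 to compound 4 (0.31 log units; beyond the scatter), with 1,3-thiazol-2-yl in place of furan-2-yl. The other two new steps are a 1.0-fold higher number from compound 3 to compound 4 (0.01 log units; within the scatter) and a 1.8-fold higher number from compound 2 to compound 4 (0.26 log units; within the scatter), so compound 4 stands apart only from compound 1, and exchanging one five-membered aromatic ring for another here still produces only small differences. Nothing available explains why this one exchange reaches past the scatter.

On these data alone, all four groups at this place are five-membered aromatic rings, so the effect of a phenyl ring, an amine or a longer alkyl chain on the same aromatic carbon remains open. Also open, as far as these compounds go, is whether a methyl group on the 1,3-thiazol-2-yl ring would shift the number at all.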